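Adding one methyl to a weakly active compound

The source may report more compounds than this note shows. Statements on the series, on what has been measured and on what is new or still open speak of the compounds shown alone.

Among the compounds with values here, compound 3 `COc1ccccc1-c1cc(O)c2cccnc2n1` stands at the top of the three numbers known so far in a functional assay on MDA-N cells (Homo sapiens) (a higher number here means a weaker inhibitor of growth, a lower number a stronger inhibitor of growth), where a high number signals weak growth inhibition. In this assay compound 3 gives 20000 nM, level with compound 2 `COc1ccccc1-c1cc(O)c2ccc(C)nc2n1` at 20000 nM. Compound 1 `COc1cccc(-c2cc(=O)c3ccc(C)nc3[nH]2)c1`, a differently built molecule, sits far lower at 11 nM.

Compound 4 `COc1ccccc1-c1cc(O)c2c(C)ccnc2n1` differs from compound 3 by a single edit, methyl in place of hydrogen on an aromatic carbon, opposite the ring nitrogen: methyl in place of hydrogen on an aromatic carbon.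

Within the data shown here, one measured step bears on this edit, since it also swaps methyl and hydrogen on an aromatic carbon of the shared core. That step, no change at the digits printed from compound 2 to compound 3 (within the scatter), involves a different carbon, so it is a guide and not a direct precedent. Among the measured compounds shown here, no measurement yet shows a methyl at the new place. For the measured compounds named here, with that single step as the only evidence, no shift beyond the scatter is expected in this assay, in either direction.

The estimated step is no change at the digits printed from compound 3 to compound 4 (within the scatter). Compound 4 is expected to give about 20000 nM, within an estimated range of 8000 nM to 40000 nM.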

Compound 4, concentration for 50% growth inhibition: 8320 nM
For compound 4 the middle estimate is 2.4-fold (0.38 log units) above the measured one; the measured number falls inside the stated range.
By their numbers in this assay, from the lowest: compound 1; then compound 4; then compounds 2 and 3 (each within the scatter of the next).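

Putting methyl in place of hydrogen on this aromatic carbon, opposite the ring nitrogen, gives a 2.4-fold lower number from compound 3 to compound 4 (0.38 log units; beyond the scatter) in this assay, and a lower number here means stronger inhibition of growth. Within the data shown here, this is the first change on the shared core that clearly registers, although it is modest in size. The earlier step, no change at the digits printed from compound 2 to compound 3 (within the scatter), exchanged the same two groups at a different carbon and stayed within the scatter, so the same small edit need not read the same at every place on this core, and no measurement on hand explains this difference between the two carbons.

On these data alone, with a single group tested at this carbon, it remains open whether the gain would grow, hold or vanish with a longer chain such as ethyl, with an amine or with a chlorine atom in the same place. As far as these compounds go, it is also open whether methyl groups at both carbons on one molecule would act together, and whether the step would stay the same size with the methoxy group placed elsewhere on its ring.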